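Varying the amide aryl group on a shared core

The compounds below may be only part of what the source reports. "The series", "measured", "known", "first", "only" and "open" are said of these compounds alone.

Three compounds with one shared core differ only in the aryl group attached to the amide carbonyl carbon. In a functional assay on GTL 16 cells for antiproliferative activity against GTL 16 cell line (Homo sapiens), read by CCK-8 assay, with a stated time of 72 h (a lower number here means a stronger inhibitor, a higher number a weaker inhibitor), compound 1 `COc1ccccc1C(=O)Nc1cccc(-c2oc3cc(-c4ccc(F)cc4)ccc3c(=O)c2O)c1` gives 6370 nM, compound 2 `COc1cc(OC)cc(C(=O)Nc2cccc(-c3oc4cc(-c5ccc(F)cc5)ccc4c(=O)c3O)c2)c1` gives 19600 nM, and compound 3 `O=C(Nc1cccc(-c2oc3cc(-c4ccc(F)cc4)ccc3c(=O)c2O)c1)c1ccc(Cl)nc1` gives 7520 nM, which leaves compound 3 second highest of the three, close to compound 1 and apart from compound 2. The relevant steps were a 1.2-fold higher number from compound 1 to compound 3 (0.07 log units; within the scatter) and a 2.6-fold lower number from compound 2 to compound 3 (0.42 log units; beyond the scatter). Compound 4 `O=C(Nc1cccc(-c2oc3cc(-c4ccc(F)cc4)ccc3c(=O)c2O)c1)c1ccc([N+](=O)[O-])cc1` carries the change (4-nitrophenyl in place of 6-chloropyridin-3-yl on a carbonyl carbon). Since the measured steps at this position range from within the scatter to a modest shift, compound 4 is expected to show a 1.0-fold lower number from compound 3 to compound 4 (0.00 log units; within the scatter) in this assay. Compound 4 is therefore estimated at 7500 nM, with a range from 3000 nM to 19000 nM.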

Compound 4, half-maximal inhibitory concentration: 18200 nM
Beside the measured number, compound 4's estimate is 2.4-fold (0.39 log units) below it; low and high end bracket the measured number.
By their numbers in this assay, from the lowest: compounds 1 and 3 (each within the scatter of the next); then compounds 4 and 2 (each within the scatter of the next).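

Placing 4-nitrophenyl on this carbonyl carbon gives a 2.4-fold higher number from compound 3 to compound 4 (0.38 log units; beyond the scatter) in this assay, and a 2.9-fold higher number from compound 1 to compound 4 (0.46 log units; beyond the scatter), so 6-chloropyridin-3-yl and 2-methoxyphenyl are not matched by every aryl group here. With a 1.1-fold lower number from compound 2 to compound 4 (0.03 log units; within the scatter), 4-nitrophenyl and 3,5-dimethoxyphenyl cannot be told apart, so two differently substituted rings give similar numbers. Nothing available explains this shift. On these data alone, whether an unsubstituted phenyl or an aminophenyl would fall with compound 1 and compound 3 or with compound 2 and compound 4 stays open. As far as these compounds go, how a carboxylic acid on the ring would behave also remains unknown.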